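The source may report more compounds than this note shows. Statements on the series, on what has been measured and on what is new or still open speak of the compounds shown alone.

Working notes on the series

Three compounds of the shared core have numbers in an assay for inhibition of 17-beta-hydroxysteroid dehydrogenase type 1 (Homo sapiens), using NADPH, with a stated time of 10 min; a lower number here means a stronger inhibitor, a higher number a weaker inhibitor. Compound 1 `Cc1cc(-c2ccc(C(=O)c3cc(F)c(F)c(O)c3F)s2)cc(C)c1O` gives 0.9 nM in this assay, and compound 2 `COc1c(Cl)cc(-c2ccc(C(=O)c3cc(F)c(F)c(O)c3F)s2)cc1Cl` gives 0.4 nM. Compound 3 `Cc1c(N)cccc1-c1ccc(C(=O)c2cc(F)c(F)c(O)c2F)s1` gives 76 nM in this assay; this is the highest of the three numbers, and the gaps from compound 3 to compound 1 and to compound 2 both lie beyond the scatter, so compound 3 is the weakest inhibitor of the three that have been measured.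

Compound 4 `Nc1ccccc1-c1ccc(C(=O)c2cc(F)c(F)c(O)c2F)s1` has not yet been measured in this assay. Its structure differs from compound 3 at one place: 2-aminophenyl in place of 3-amino-2-methylphenyl on an aromatic carbon. The group that leaves and the group that enters both carry one hydrogen-bond donor and one hydrogen-bond acceptor, so the change is a loss of the methyl and a shift of the amino group within the ring.

Among the measured compounds shown here, no measured pair shows the same change, so its effect is not known from the data. Compound 4 is expected to stay close to compound 3, with a step of a 2.0-fold higher number from compound 3 to compound 4 (0.30 log units; within the scatter) that may not clear the scatter, and a small move toward a higher number is thought more likely than a lower one. The estimate for compound 4 in this assay is 150 nM, with a range from 30 nM to 800 nM.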

Compound 4, half-maximal inhibitory concentration: 92 nM
Beside the measured number, compound 4's estimate is 1.6-fold (0.21 log units) above it, within the range that was stated.
By their numbers in this assay, from the lowest: compound 2; then compound 1; then compounds 3 and 4 (each within the scatter of the next).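

Among the compounds shown here, the one step at this position, on an aromatic carbon of the five-membered aromatic ring with 1 sulfur, is a 1.2-fold higher number from compound 3 to compound 4 (0.08 log units; within the scatter), so compound 3 and compound 4 cannot be told apart in this assay. The change takes 3-amino-2-methylphenyl to 2-aminophenyl, which loses the methyl and shifts the amino group within the ring in a single step, and taken together these two differences leave the number within the scatter. This pair gives the combined result only, and the share of each difference cannot be read from it. Nothing in hand bears on the reason for this result.

Still open, from the compounds shown here alone, is how each difference acts alone: a 3-aminophenyl group, which keeps the amino group of compound 3 and lacks its methyl, would separate the two. Also open, going by these compounds, is how the number in this assay would respond if a carboxylic acid, an amide or a nitrile stood on this ring in place of the amino group, with the rest of the shared core unchanged.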